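Fluoro to Hydrogen: From Compound 1 to Compound 4

The compounds below may be only part of what the source reports. "The series", "measured", "known", "first", "only" and "open" are said of these compounds alone.

Compound 1 `O=C(/C=C/c1coc2cc(O)ccc2c1=O)NCc1ccc(F)cc1` carries a 4-fluorobenzyl group on an amide-type nitrogen. In a functional assay (QGY7701 cells, Homo sapiens) for inhibition, read by MTT assay, with a stated time of 48 h (on this read-out higher numbers stand for weaker inhibition and lower numbers for stronger inhibition), compound 1 gives > 100000 nM, which is a limit of the assay rather than a number. Among the three measured compounds, compound 1 is one of the two that sit at the limit of > 100000 nM in this assay, at which 2 of the 3 values shown sit, the other being compound 3 `COc1ccc2c(=O)c(/C=C/C(=O)Nc3cc(C)ccc3C)coc2c1`. In this assay compound 3 gives > 100000 nM, again a limit. Within the data shown here, compound 2 `COc1ccc2c(=O)c(/C=C/C(=O)NCc3cccc(F)c3)coc2c1` is the only one that returns a number. In this assay compound 2 gives 28600 nM. Among the measured compounds shown here, the single measured step, an at least 3.4-fold higher number from compound 2 to compound 3 (0.54 log units; beyond the scatter), concerns the group on the amide-type nitrogen and not the fluoro, and compound 1 and compound 2 differ in more than one place, so nothing measured bears directly on the change now in question.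

Compound 4 `O=C(/C=C/c1coc2cc(O)ccc2c1=O)NCc1ccccc1` differs from compound 1 by hydrogen in place of fluoro on an aromatic carbon. For the measured compounds named here, with no step of this kind measured, and with compound 1 itself showing only a limit, the author expects no step beyond the scatter, and most likely another limit. Compound 4 is therefore estimated at 150000 nM, with a range of 30000 nM to 600000 nM. That expectation corresponds to a step that the limit leaves unreadable from compound 1 to compound 4.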

Compound 4, half-maximal inhibitory concentration: 63000 nM
Compound 4: the middle estimate sits 2.4-fold (0.38 log units) above what was measured; the measured number falls inside the stated range.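

In this assay compound 4 gives 63000 nM, so the benzyl group on the amide-type nitrogen of this core returns a number, which the 4-fluorobenzyl group of compound 1 does not. Compound 1 gives > 100000 nM, which is a limit of the assay and not a number. Hydrogen in place of fluoro on an aromatic carbon, para to a large group, comes to an at least 1.5-fold lower number from compound 1 to compound 4 (0.20 log units; that floor lies within the scatter), so the change may be no larger than the usual scatter, and its true size cannot be read because one end of it rests on a limit: the limit of > 100000 nM in this assay, at which 2 of the 4 values shown sit.

The compounds shown leave open whether another group at this place, such as chloro, methoxy or an amine, would move the number clearly beyond the scatter. Among these compounds, the change from fluoro to hydrogen is also seen only on the core of compound 1, so it remains open whether it would read the same on the methoxy-bearing core of compound 2, or with the fluoro on the 3-fluorobenzyl group of that compound.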